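The source may hold more compounds than are shown below. What is called first, only, known or untested is meant among the compounds shown, and "the series" means these compounds.

Compound 1, `COc1ccccc1CNc1ncnc2c1ncn2C1CCCCO1`, gives in an ADME assay on BJ cells (Homo sapiens) for cytotoxicity, read by MTT assay, with a stated time of 72 h (a lower number here means a stronger inhibitor, a higher number a weaker inhibitor), a value of > 100000 nM, which is a limit of the assay rather than a number.
Compound 2, `COc1cccc(OC)c1CNc1ncnc2c1ncn2C1CCCCO1`, gives in this assay > 100000 nM, again a limit.
Compound 3, `COc1ccc(CNc2ncnc3c2ncn3C2CCCCO2)cc1OC`, gives in this assay > 100000 nM, also a limit.

Compound 1 and compound 2 differ by one change, (methoxy in place of hydrogen on an aromatic carbon), and the step that the two limits leave unreadable from compound 1 to compound 2 stays unreadable because both values sit at the limit of > 100000 nM in this assay, at which 3 of the 3 values shown sit. How the core of compound 3 differs from the core of compound 1 is not broken down here.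

Compound 4, `COc1ccc(CNc2ncnc3c2ncn3C2CCCCO2)c(OC)c1OC`, has not yet been measured. It differs from compound 3 by methoxy in place of hydrogen on an aromatic carbon. The surroundings are not identical to those of the first change: in compound 4 the entering methoxy is also ortho to a methoxy group, so this is the same kind of change rather than the same change.

The step that the limit leaves unreadable from compound 3 to compound 4 is expected to be small, since compound 3 already gives > 100000 nM and the earlier change left compound 2 at > 100000 nM. Compound 4 is therefore estimated at 150000 nM, most likely reported again only as a limit.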

Compound 4, half-maximal inhibitory concentration: > 37500 nM
Compound 4: only a limit was reported; the forecaster's own chance of this, stated with the estimate: 85%; the middle value does not contradict the limit.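

Compound 3 and compound 4 are both reported in this assay only as limits of the assay, not as numbers, so the size of the step between them cannot be read. The compounds shown leave open how strongly any of them actually acts on these cells, and whether methoxy in place of hydrogen changes that at all.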